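Methyl for methoxy on the benzylic ring: compound 4 estimated

The compounds below may be only part of what the source reports. "The series", "measured", "known", "first", "only" and "open" are said of these compounds alone.

Compound 3 `COc1cccc(COc2ccc(-c3nn(CCC#N)c(=S)o3)cc2)c1` gives 8100 nM in an assay for inhibition of Amine oxidase [flavin-containing] A (Rattus norvegicus); a higher number here means a weaker inhibitor, a lower number a stronger inhibitor. Among the three compounds measured, compound 3 stands second highest: its nearest neighbour is compound 2 `N#CCCn1nc(-c2ccc(OCc3cccc(Cl)c3)cc2)oc1=O`, which gives 7400 nM, a gap within the scatter; furthest is compound 1 `Cc1ccc(COc2ccc(-c3nn(CCC#N)c(=O)o3)cc2)cc1`, which gives 25000 nM, a gap beyond the scatter. Among the measured compounds shown here, the one measured step, a 3.4-fold lower number from compound 1 to compound 2 (0.53 log units; beyond the scatter), is modest and concerns the ring on the chain carbon bound to the aromatic oxygen. Compound 4 `Cc1cccc(COc2ccc(-c3nn(CCC#N)c(=S)o3)cc2)c1` differs from compound 3 in that same ring: methyl in place of methoxy on an aromatic carbon, on an aromatic carbon meta to a large group. For the measured compounds named here, no measured step exchanges methoxy for methyl, and the only step that touches this ring, from compound 1 to compound 2, was modest. The author therefore expects compound 4 to show a step of a 1.2-fold lower number from compound 3 to compound 4 (0.06 log units; within the scatter), within the scatter. For compound 4 the estimate is 7000 nM, between 2500 nM and 20000 nM.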

Compound 4, half-maximal inhibitory concentration: 14000 nM
Beside the measured number, compound 4's estimate is 2.0-fold (0.30 log units) below it; the measured number falls inside the stated range.
By their numbers in this assay, from the lowest: compounds 2, 3, 4 and 1 (each within the scatter of the next, the first and the last beyond it).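

In this assay, the exchange of methoxy for methyl on an aromatic carbon meta to a large group gives a 1.7-fold higher number from compound 3 to compound 4 (0.24 log units; within the scatter), so at this place the change from 3-methoxyphenyl to 3-methylphenyl is not resolved from the usual scatter of the assay. The earlier step from 4-methylphenyl to 3-chlorophenyl altered both the group and its place on the ring, whereas this pair holds the place fixed and shows that losing the methoxy oxygen, with its one hydrogen-bond acceptor, leaves a step no larger than the scatter. No supporting evidence is available to explain this result. From the compounds shown here alone, whether an amine or a carboxylic acid at this same place would give a step beyond the scatter remains open. So does whether methyl for methoxy would read the same on the core of compound 1.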